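The source may hold more compounds than are shown below. What is called first, only, known or untested is meant among the compounds shown, and "the series" means these compounds.

Measured in a functional assay on G-361 cells (Homo sapiens) for antiproliferative activity, with a stated time of 72 h; on this read-out higher numbers stand for weaker inhibition and lower numbers for stronger inhibition:
- compound 1 `OC[C@H]1O[C@@H](n2cnc3c(NCc4ccccc4F)ncnc32)[C@H](O)[C@@H]1O`: "not determined" (no result reported)
- compound 2 `OC[C@H]1O[C@@H](n2cnc3c(NCc4ccc(F)cc4)ncnc32)[C@H](O)[C@@H]1O`: > 166000 nM (a limit)
- compound 3 `OC[C@H]1O[C@@H](n2cnc3c(NCc4ccc(Cl)cc4)ncnc32)[C@H](O)[C@@H]1O`: > 166000 nM (a limit)

Compound 3 has no number, only the limit > 166000 nM. Its standing in the series is therefore open, and the same holds for the other entries: the data offer only (the limit of > 166000 nM in this assay, at which 2 of the 3 values shown sit), and compound 1 has no result.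

Compound 4 `OC[C@H]1O[C@@H](n2cnc3c(NCc4ccccc4Br)ncnc32)[C@H](O)[C@@H]1O` is the next case, with 2-bromophenyl in place of 4-chlorophenyl on a saturated chain carbon bound to a nitrogen on an aromatic ring.

Within the data shown here, the one measured step that bears on this change is a step that the two limits leave unreadable from compound 2 to compound 3. It has no readable size and concerns a different halogen swap, so it gives no direction. The working expectation in this assay is therefore no clear step, with a reported limit quite likely. The expected change is an at least 1.2-fold lower number from compound 3 to compound 4 (0.10 log units; that floor lies within the scatter).

For compound 4 the estimated value is 130000 nM, with an expected range of 30000 nM to 220000 nM.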

Compound 4, half-maximal inhibitory concentration: > 166000 nM
Compound 4: no number, only a limit; the forecaster's own chance of this, stated with the estimate: 60%; at least 1.2-fold (0.10 log units) between middle value and limit.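

Compound 2, compound 3 and compound 4 each carry only a limit, and no step among them can be read: the limit of > 166000 nM in this assay, at which 3 of the 4 values shown sit.

The compounds shown leave open whether 4-fluorophenyl, 4-chlorophenyl and 2-bromophenyl differ at all in effect, and where compound 1, with no reported result, stands.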